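Swapping trifluoromethyl for methoxymethyl on the aromatic ring

The source may report more compounds than this note shows. Statements on the series, on what has been measured and on what is new or still open speak of the compounds shown alone.

Measured so far:
compound 1 `CCc1cccc(C[C@H](O)/C=C/[C@H]2CSC(=O)N2CCSCCCC(=O)O)c1` — 0.88 nM
compound 2 `O=C(O)CCCSCCN1C(=O)SC[C@@H]1/C=C/[C@@H](O)Cc1cccc(C(F)(F)F)c1` — 0.97 nM

In an assay on CHO cells for displacement of a labelled ligand from prostaglandin E2 receptor EP4 subtype (Mus musculus), read by scintillation counting, with a stated time of 60 min (a higher number here means a weaker inhibitor, a lower number a stronger inhibitor), compound 1 gives 0.88 nM and compound 2 gives 0.97 nM. Of the two numbers, compound 2 has the higher one, but the gap a 1.1-fold higher number from compound 1 to compound 2 (0.04 log units; within the scatter) lies within the scatter, so the two cannot be told apart. Compound 3 `COCc1cccc(C[C@H](O)/C=C/[C@H]2CSC(=O)N2CCSCCCC(=O)O)c1` differs from compound 2 by methoxymethyl in place of trifluoromethyl on an aromatic carbon. Among the compounds with values here, the one measured step bears directly on this place, since it also exchanged the group on that aromatic carbon, and it stayed within the scatter. Two different groups there gave numbers that overlap, so a third group of similar size is expected to do the same. For compound 3 the expected step is a 1.2-fold higher number from compound 2 to compound 3 (0.09 log units; within the scatter), no change beyond the scatter. Compound 3 is estimated at 1.2 nM, with a range from 0.4 nM to 4 nM.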

Compound 3, inhibition constant: 1.2 nM
Estimate against measurement, compound 3: no gap at the digits printed, within the range that was stated.
By their numbers in this assay, from the lowest: compounds 1, 2 and 3 (each within the scatter of the next).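

In this assay both a 1.2-fold higher number from compound 2 to compound 3 (0.09 log units; within the scatter) and a 1.4-fold higher number from compound 1 to compound 3 (0.13 log units; within the scatter) leave the numbers indistinguishable, so three different groups on this aromatic carbon now read alike. Methoxymethyl is the first group in this set with a hydrogen-bond acceptor, which trifluoromethyl lacks, and adding it brings no change beyond the scatter. Compared with compound 1, the change amounts to methoxy in place of methyl on the chain carbon bound to the ring, and this too gives no separable change. No measurement shown here explains why these groups read alike.

Going by these compounds, it remains open whether this tolerance extends to an amine, a carboxylic acid, a longer chain or an added ring on this carbon. On these data alone, these numbers also come from one receptor only, so how the compounds compare on any other receptor stays unknown.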